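This account rests on a few compounds, and the source may have more. Where it says the series, first, only, none or still open, it means among the compounds named here.

Measured so far:
compound 1 `COc1ccc(/C=C/C[C@H]2C[C@@H]([C@@H](O)c3ccc(OC)c(OC)c3)CO[C@@H]2c2ccccc2)cc1OC`: 17000 nM
compound 2 `COc1ccc([C@H]2OC[C@H]([C@@H](O)c3ccc(OC)c(OC)c3)C[C@@H]2C/C=C/c2ccc(OC)c(OC)c2)cc1`: 46700 nM
compound 3 `COc1ccc(/C=C/C[C@@H]2C[C@@H]([C@@H](O)c3ccc(OC)c(OC)c3)CO[C@H]2c2ccc(OC)c(OC)c2)cc1OC`: 30600 nM

In a functional assay on HeLa cells (Homo sapiens) for cytotoxicity, read by WST assay, with a stated time of 48 h (on this read-out lower numbers stand for stronger inhibition and higher numbers for weaker inhibition), compound 1 gives 17000 nM, compound 2 gives 46700 nM, and compound 3 gives 30600 nM. Compound 2 and compound 1 differ by hydrogen in place of methoxy on an aromatic carbon, and this change made the step of a 2.7-fold lower number from compound 2 to compound 1 (0.44 log units; beyond the scatter). How the core of compound 3 differs from the core of compound 2 is not broken down here. Compound 4 `COc1ccc([C@H](O)[C@H]2CO[C@@H](c3ccc(OC)c(OC)c3)[C@H](C/C=C/c3ccc(OC)c(OC)c3)C2)cc1` is not yet measured in this assay; it differs from compound 3 by hydrogen in place of methoxy on an aromatic carbon. This is the same kind of change as from compound 2 to compound 1, but the place differs: there the leaving methoxy stood para to a large group, here it stands ortho to a methoxy group and meta to a large group. Among the measured compounds shown here, only one measured step of this kind is known, so the expected step of a 1.7-fold lower number from compound 3 to compound 4 (0.23 log units; within the scatter) is modest and rests on a 2.7-fold lower number from compound 2 to compound 1 (0.44 log units; beyond the scatter). Compound 4 is estimated at 18000 nM, expected to fall between 7000 nM and 50000 nM.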

Compound 4, half-maximal inhibitory concentration: 32200 nM
The estimate for compound 4 lay 1.8-fold (0.25 log units) below the measured number; the range from low to high includes it.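

In this assay, taking away one methoxy group and leaving hydrogen gives a 1.1-fold higher number from compound 3 to compound 4 (0.02 log units; within the scatter), so on this core the change cannot be told apart from no change. The change therefore does not carry over with the same size from one core to the other: the same change on two cores in this assay, a 2.7-fold lower number (0.44 log units; beyond the scatter) from compound 2 to compound 1 and a 1.1-fold higher number (0.02 log units; within the scatter) from compound 3 to compound 4, 2.9-fold (0.46 log units) apart, beyond the scatter of two such steps. Among the compounds shown here, with only two such steps, and the methoxy leaving from a different place in each, this does not show whether the core or the place accounts for the gap, and it gives no rule for other cores.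

Open, from the compounds shown here alone, is what a group other than methoxy or hydrogen on these aromatic carbons, such as an amine or a carboxylic acid, would do in this assay.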